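The compounds below may be only part of what the source reports. "The series", "measured", "known", "first", "only" and "open" are said of these compounds alone.

Measured so far in an assay on isolated protein for inhibition of polyamine deacetylase HDAC10 (Homo sapiens); a lower number here means a stronger inhibitor, a higher number a weaker inhibitor:
- compound 1, `COc1ccc(C(=O)c2ccc3c(ccn3Cc3ccc(C(=O)NO)cc3)c2)cc1`: 59800 nM
- compound 2, `O=C(NO)c1ccc(Cn2ccc3cc(C(=O)c4ccc(Cl)cc4)ccc32)cc1`: a limit only, > 100000 nM
- compound 3, `Cc1ccc(C(=O)c2ccc3c(ccn3S(=O)(=O)c3cccc(/C=C/C(=O)NO)c3)c2)cc1`: 9100 nM

Compound 3 stands at the lowest of the two numbers shown in this assay; the nearest number is that of compound 1, which is higher by a gap beyond the scatter. For compound 2 this assay reports only a limit, (the limit of > 100000 nM in this assay, at which 1 of the 3 values shown sits).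

Compound 4, `COc1ccc(C(=O)c2ccc3c(ccn3S(=O)(=O)c3cccc(/C=C/C(=O)NO)c3)c2)cc1OC`, differs from compound 3 by 3,4-dimethoxyphenyl in place of 4-methylphenyl on a carbonyl carbon. For the measured compounds named here, the single measured step, an at least 1.6-fold higher number from compound 1 to compound 2 (0.22 log units; that floor lies within the scatter), also alters the substituent on the phenyl group bound to the carbonyl carbon, but it swaps a methoxy for a chloro rather than adding methoxy groups in place of a methyl, and its size sits at a floor within the scatter. Going by the values given here, no measured pair shows the 4-methylphenyl to 3,4-dimethoxyphenyl exchange itself. The expectation for this assay is therefore a step of a 1.1-fold lower number from compound 3 to compound 4 (0.06 log units; within the scatter), not beyond the scatter. Compound 4 is estimated at 8000 nM, in the range 2500 nM to 30000 nM.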

Compound 4, half-maximal inhibitory concentration: 8240 nM
The estimate for compound 4 lay 1.0-fold (0.01 log units) below the measured number; measured number inside the range.
By their numbers in this assay, from the lowest: compounds 4 and 3 (each within the scatter of the next); then compound 1. At a limit, above all of these: compound 2.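

In this assay, the exchange of 4-methylphenyl for 3,4-dimethoxyphenyl on a carbonyl carbon gives a 1.1-fold lower number from compound 3 to compound 4 (0.04 log units; within the scatter), so this position takes a larger group, with 10 heavy atoms against 7 and 2 hydrogen-bond acceptors against 0, with no change in the number beyond the scatter. For the compounds shown here, compound 2, at the far end of the only earlier step at this place, carries a limit, so this is the first exchange here with a number at both ends. No measured property in hand bears on this result.

Going by these compounds, whether an amine or a carboxylic acid on this phenyl would move the number beyond the scatter stays open. So does whether 3,4-dimethoxyphenyl would read the same on the core of compound 1.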